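The compounds below may be only part of what the source reports. "The series", "measured", "known", "first", "only" and "open" are said of these compounds alone.

Measured so far: compound 1 `CCOc1ccc(/C=C(\C(=O)c2ccc(Cl)cc2)S(=O)(=O)Cc2ccc(C)cc2)cc1OC` gives 10000 nM in a functional assay on DU-145 cells (Homo sapiens) for inhibition, read by trypan blue exclusion, with a stated time of 96 h; a lower number here means a stronger inhibitor of growth, a higher number a weaker inhibitor of growth. Compound 3 `Cc1ccc(CS(=O)(=O)/C(=C/c2cc(C)cc(C)c2)C(=O)c2ccc(Cl)cc2)cc1` gives 10000 nM in this assay. Compound 2 `Cc1ccc(CS(=O)(=O)/C(=C/c2c(O)cc(O)cc2O)C(=O)c2ccc(Cl)cc2)cc1` reaches only a limit of the assay, > 100000 nM.

Compound 1 stands level with compound 3, the step of no change at the digits printed from compound 1 to compound 3 (within the scatter) lying within the scatter, while an at least 10-fold higher number from compound 1 to compound 2 (1.00 log units; beyond the scatter) runs up to the limit (the limit of > 100000 nM in this assay, at which 1 of the 3 values shown sits). Compound 4 `CCOc1ccc(/C=C(/SCc2ccc(Cl)c(Cl)c2)C(=O)c2ccc(Cl)cc2)cc1OC` keeps the aryl group of compound 1 and changes the sulfur side instead: (3,4-dichlorobenzyl)sulfanyl in place of (4-methylbenzyl)sulfonyl on a double-bonded chain carbon bound to a carbonyl carbon and a double-bonded chain carbon. Among the measured compounds shown here, every measured step swaps the aryl on the other double-bonded chain carbon, so none of them bears directly on this change, and the swap of (4-methylbenzyl)sulfonyl for (3,4-dichlorobenzyl)sulfanyl has no measured precedent here. Without such evidence, no step beyond the scatter is expected, no change at the digits printed from compound 1 to compound 4 (within the scatter). Compound 4 is therefore estimated at 10000 nM, between 2000 nM and 50000 nM.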

Compound 4, concentration for 50% growth inhibition: 25000 nM
Estimate against measurement, compound 4: 2.5-fold (0.40 log units) below, within the range that was stated.
By their numbers in this assay, from the lowest: compounds 1 and 3 (each within the scatter of the next); then compound 4. At a limit, above all of these: compound 2.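

In this assay, among the compounds shown here, the first swap on the sulfur side gives a 2.5-fold higher number from compound 1 to compound 4 (0.40 log units; beyond the scatter), so this position does affect the read-out, though the sulfonyl is not needed for a measurable value. The swap changes the sulfur link and the groups on the benzyl ring together, so the step cannot be assigned to either change alone. Nothing available here explains the step. Still open, going by these compounds, is how (4-methylbenzyl)sulfanyl or (3,4-dichlorobenzyl)sulfonyl would read, which would separate the two changes, and how an amine or a carboxylic acid would fare at this place.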